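This account rests on a few compounds, and the source may have more. Where it says the series, first, only, none or still open, it means among the compounds named here.

Measured so far:
- Compound 1, `COc1cc(C2=NN(C(C)=O)C(c3ccccc3C(F)(F)F)O2)cc(OC)c1OC`: 15.2%
- Compound 2, `COc1cc(C2=NN(C(C)=O)C(c3c(Cl)cccc3Cl)O2)cc(OC)c1OC`: -2.2%
- Compound 3, `COc1cc(C2=NN(C(C)=O)C(c3cccc(OC)c3OC)O2)cc(OC)c1OC`: 58.2%

These three compounds share one core and differ only in the aryl group on a saturated ring carbon. In a functional assay on PC-3 cells (Homo sapiens) for antiproliferative activity, read by MTT assay, tested at 5 uM (on this read-out higher numbers stand for a stronger effect at the one concentration tested and lower numbers for a weaker effect), compound 3 gives 58.2%, the highest of the three numbers; its nearest neighbour is compound 1, and the distance to compound 2 is even larger, both gaps lying beyond the scatter.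

Compound 4, `COc1cc(C2=NN(C(C)=O)C(c3ccc(C(F)(F)F)cc3)O2)cc(OC)c1OC`, has not yet been measured. It differs from compound 3 in one place: 4-(trifluoromethyl)phenyl in place of 2,3-dimethoxyphenyl on a saturated ring carbon.

Within the data shown here, two measured steps bear on this change, both running toward the 2,3-dimethoxyphenyl group rather than away from it: a number 43 percentage points higher from compound 1 to compound 3 (beyond the scatter) and a number 60.4 percentage points higher from compound 2 to compound 3 (beyond the scatter). Reversing the first of them is the closest guide, although the trifluoromethyl group now sits on a different ring position than in compound 1, and that difference has not been tested. A decrease beyond the scatter is therefore expected for compound 4, estimated as a number 38.2 percentage points lower from compound 3 to compound 4 (beyond the scatter). The value of compound 4 in this assay is estimated at 20%, within a range from 0% to 45%.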

Compound 4, a percentage reported as inhibition, at one concentration (the size of the read-out at that concentration, not a potency): -0.7%
Compound 4: middle estimate off by 20.7 percentage points, on the high side; the whole stated range lies above it.
By their numbers in this assay, from the lowest: compounds 2 and 4 (each within the scatter of the next); then compound 1; then compound 3.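

Replacing 2,3-dimethoxyphenyl with 4-(trifluoromethyl)phenyl gives a number 58.9 percentage points lower from compound 3 to compound 4 (beyond the scatter) in this assay, so the high number of compound 3 is not matched by this new aryl group. The place of the trifluoromethyl group on the phenyl ring also counts, since moving it from the 2-position to the 4-position gives a number 15.9 percentage points lower from compound 1 to compound 4 (beyond the scatter) in this series. Replacing 2,6-dichlorophenyl with 4-(trifluoromethyl)phenyl gives a number 1.5 percentage points higher from compound 2 to compound 4 (within the scatter) and so shows no separation between these two aryl groups, leaving 2,3-dimethoxyphenyl clearly highest among the four.

No measurement shown gives a reason for these differences. On these data alone, it remains open whether both methoxy groups are needed, and how a phenyl ring carrying an amine or a carboxylic acid would behave at this position.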